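This account rests on a few compounds, and the source may have more. Where it says the series, first, only, none or still open, it means among the compounds named here.

Values in an ADME assay on HEp-2 cells (Homo sapiens) for cytotoxicity; a higher number here means that more compound is tolerated, a lower number that less compound is tolerated:
- Compound 1 `CC(C)CCn1c(Cn2c(=O)n(C(C)C)c3ccccc32)nc2cc(CNS(C)(=O)=O)ccc21`: 30800 nM
- Compound 2 `CC(C)CCn1c(Cn2c(=O)n(C(C)C)c3ccccc32)nc2cc(CF)ccc21`: 37300 nM
- Compound 3 `C=Cc1ccc2c(c1)nc(Cn1c(=O)n(C(C)C)c3ccccc31)n2CCC(C)C`: 6520 nM

Compound 3, at 6520 nM, has the lowest of these three numbers, and both other compounds lie beyond the scatter from it. Still unmeasured is compound 4 `CC(C)CCn1c(Cn2c(=O)n(C(C)C)c3ccccc32)nc2cc(C(=O)N(C)C)ccc21`, which carries dimethylcarbamoyl in place of vinyl on an aromatic carbon.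

Two measured steps swap a group at that same carbon and end on vinyl. The first is a 4.7-fold lower number from compound 1 to compound 3 (0.67 log units; beyond the scatter), and the second is a 5.7-fold lower number from compound 2 to compound 3 (0.76 log units; beyond the scatter). Without vinyl, the number stays high in both measured cases, even though (methanesulfonamido)methyl and fluoromethyl are quite different groups: a 1.2-fold higher number from compound 1 to compound 2 (0.08 log units; within the scatter). For the measured compounds named here, no measured compound carries dimethylcarbamoyl, so this is only a reading across from other groups.

Compound 4 is therefore expected to return to the range of compound 1 at 30800 nM and compound 2 at 37300 nM, a modest rise in this assay and of similar size to those two steps. The estimated step is a 4.3-fold higher number from compound 3 to compound 4 (0.63 log units; beyond the scatter). For compound 4 the estimated value is 28000 nM, with an expected range from 11000 nM to 70000 nM.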

Compound 4, half-maximal cytotoxic concentration: 25600 nM
Beside the measured number, compound 4's estimate is 1.1-fold (0.04 log units) above it, and the stated range covers the measured number.
By their numbers in this assay, from the lowest: compound 3; then compounds 4, 1 and 2 (each within the scatter of the next).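

In this assay, the dimethylcarbamoyl group at this aromatic carbon gives a clear rise over vinyl (a 3.9-fold higher number from compound 3 to compound 4 (0.59 log units; beyond the scatter)), even though both groups contain one double bond outside the aromatic rings, so having such a bond does not by itself go with the lower number. Compound 4 also shows no separation from the two other non-vinyl compounds (a 1.5-fold lower number from compound 2 to compound 4 (0.16 log units; within the scatter); a 1.2-fold lower number from compound 1 to compound 4 (0.08 log units; within the scatter)), which leaves compound 3 as the only one of these four standing apart, while dimethylcarbamoyl, fluoromethyl and (methanesulfonamido)methyl cannot be told apart here. No measurement is available to explain why vinyl differs from the other three groups.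

Going by these compounds, it remains open whether the lower number depends on the vinyl double bond specifically, and ethyl, which has two carbons and no double bond, would address that question at the same aromatic carbon. Also open, on these data alone, is whether an amine or a carboxylic acid at this carbon would match compound 3 or the other three compounds in this assay.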